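This account rests on a few compounds, and the source may have more. Where it says the series, first, only, none or still open, it means among the compounds named here.

Compound 3 (`CCCOC(=O)NC(=O)c1ccsc1NC(=O)c1ccc(S(=O)(=O)N2CCOCC2)cc1`) has no number to stand on in a toxicity assay on Vero cells (Chlorocebus sabaeus) for cytotoxicity, read by MTT assay; a higher number here means a weaker inhibitor, a lower number a stronger inhibitor: its entry reads "nd" (no result reported), meaning no result was reported. The step to compound 4 (`Cc1ccnc(NC(=O)c2ccsc2NC(=O)c2ccc(S(=O)(=O)N3CCOCC3)cc2)n1`) is 4-methylpyrimidin-2-yl in place of propoxycarbonyl on an amide-type nitrogen, so 4-methylpyrimidin-2-yl takes the place of propoxycarbonyl on an amide-type nitrogen. Among the compounds with values here, only one measured step bears on this change. In this assay, compound 1 (`CCCOC(=O)NC(=O)c1ccsc1NC(=O)c1ccc(S(=O)(=O)N2CCCCC2)cc1`) gives 56.6 ug/mL and compound 2 (`Cc1ccnc(NC(=O)c2ccsc2NC(=O)c2ccc(S(=O)(=O)N3CCCCC3)cc2)n1`) gives 32.8 ug/mL. The same exchange between them is a 1.7-fold lower number from compound 1 to compound 2 (0.24 log units; within the scatter). A step of no size beyond the scatter, in either direction, is therefore expected for this exchange in this assay. With no value for compound 3 to start from, the expectation has to rest on the two measured neighbours, and this single pair is thin support. The estimate also sits closer to compound 2 because 32.8 ug/mL comes from the compound carrying the same incoming group. Compound 4 is expected to give about 40 ug/mL, with an estimated range of 15 ug/mL to 105 ug/mL.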

Compound 4, half-maximal inhibitory concentration: 42.7 ug/mL
Estimate against measurement, compound 4: 1.1-fold (0.03 log units) below, within the range that was stated.
By their numbers in this assay, from the lowest: compounds 2, 4 and 1 (each within the scatter of the next).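

Within the data shown here, compound 4 gives the first reading at the sulfonyl sulfur, where morpholin-4-yl takes the place of piperidin-1-yl: in this assay this exchange is a 1.3-fold higher number from compound 2 to compound 4 (0.11 log units; within the scatter). With 4-methylpyrimidin-2-yl on the amide-type nitrogen, the two rings on the sulfonyl sulfur therefore cannot be told apart by this read-out. Nothing available accounts for this result.

With no result reported for compound 3, the exchange of propoxycarbonyl for 4-methylpyrimidin-2-yl cannot be read directly on the morpholin-4-yl compounds, and it still rests on a single pair. Also open, as far as these compounds go, is whether a different amine on the sulfonyl sulfur, such as piperazine or dimethylamine, or a longer chain than propoxycarbonyl on the amide-type nitrogen, such as hexyloxycarbonyl, would give a step beyond the scatter.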